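This account rests on a few compounds, and the source may have more. Where it says the series, first, only, none or still open, it means among the compounds named here.

Measured so far:
- compound 1 `OC1CCN(c2ccc(-c3ccccc3)nn2)CC1`: 83 mg/kg
- compound 2 `OC1CCN(c2ccc(-c3ccccc3Cl)nn2)CC1`: 38 mg/kg
- compound 3 `O=[N+]([O-])c1ccccc1-c1ccc(N2CCC(O)CC2)nn1`: 81 mg/kg

All three were run in a functional assay on the whole organism with Mus musculus as the target; on this read-out higher numbers stand for an effect only at larger amounts of compound and lower numbers for an effect already at smaller amounts. Compound 1 holds the highest of the three numbers; compound 3 lies within the scatter of it, and only compound 2 sits apart, the step being a 2.2-fold lower number from compound 1 to compound 2 (0.34 log units; beyond the scatter). The step with nitro in place of hydrogen on an aromatic carbon, a 1.0-fold lower number from compound 1 to compound 3 (0.01 log units; within the scatter), gave no movement beyond the scatter, and the swap of nitro for chloro, a 2.1-fold higher number from compound 2 to compound 3 (0.33 log units; beyond the scatter), brought the number back up to where compound 1 stands.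

Compound 4 `O=[N+]([O-])c1ccc(-c2ccc(N3CCC(O)CC3)nn2)cc1` has not yet been measured. Against compound 1 the change is nitro in place of hydrogen on an aromatic carbon. For the measured compounds named here, the one step that bears on it directly is that from compound 1 to compound 3, which stayed within the scatter, though there the nitro sat at a different place on the same ring; compound 2 shows that a small substituent can shift the number modestly. Taken together, no step beyond the scatter is expected. Compound 4 is therefore expected to show a 1.1-fold lower number from compound 1 to compound 4 (0.04 log units; within the scatter), with an estimate of 75 mg/kg in a range from 35 mg/kg to 160 mg/kg.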

Compound 4, dose for half-maximal effect: 54 mg/kg
For compound 4 the middle estimate is 1.4-fold (0.14 log units) above the measured one, and the stated range covers the measured number.
By their numbers in this assay, from the lowest: compounds 2, 4, 3 and 1 (each within the scatter of the next, the first and the last beyond it).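

The nitro, para to a large group, gives a 1.5-fold lower number from compound 1 to compound 4 (0.19 log units; within the scatter) in this assay, so this second placing of the nitro also stays without a step beyond the scatter. Compound 3 at 81 mg/kg and compound 4 at 54 mg/kg lie within the scatter of each other, so these two numbers do not separate the two placings of the nitro on this ring. No measurement at hand bears on why the number behaves this way.

On these data alone, whether an amine or a carboxylic acid at this same place would give a step beyond the scatter remains open. Also open, as far as these compounds go, is whether chloro at this place would give a step like a 2.2-fold lower number from compound 1 to compound 2 (0.34 log units; beyond the scatter).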